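Swapping the Aryl Ester Tail on a Methylated Core

The compounds below may be only part of what the source reports. "The series", "measured", "known", "first", "only" and "open" are said of these compounds alone.

Compound 2 `Cc1c(OCCCCOc2ccccc2C(=O)O)ccc(C(=O)CC2CCCC2)c1C`, compound 3 `Cc1c(OCCCCOc2ccccc2C(=O)O)ccc(C(=O)CC2CCCC2)c1O` and compound 1 `COC(=O)c1ccc(OCCCCOc2ccc(C(=O)CC3CCCC3)c(O)c2C)cc1` share one core and differ at two places. In an assay on HEK293 cells for positive allosteric modulation of metabotropic glutamate receptor 3 (Rattus norvegicus), read by thallium flux, with a stated time of 2.5 min (a higher number here means a larger maximal response, a lower number a smaller maximal response), compound 2 gives 28%. Compound 3 gives 32.9% and compound 1 gives 22%, so compound 2 sits among the three numbers without being separated from either neighbour by more than the usual scatter (a number 4.9 percentage points higher from compound 2 to compound 3 (within the scatter); the gap to compound 1 is of similar size).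

Compound 4 `COC(=O)c1ccc(OCCCCOc2ccc(C(=O)CC3CCCC3)c(C)c2C)cc1` has not yet been measured. It differs from compound 2 by 4-(methoxycarbonyl)phenyl in place of 2-carboxyphenyl on an oxygen on a saturated carbon. The step from compound 1 to compound 3 is this very exchange run backwards, on a core that carries a hydroxy where compound 2 and compound 4 carry a methyl: a number 10.9 percentage points higher from compound 1 to compound 3 (beyond the scatter). Since that hydroxy-for-methyl swap itself changed little (a number 4.9 percentage points higher from compound 2 to compound 3 (within the scatter)), a drop of about the same size is expected for compound 4: a number 10 percentage points lower from compound 2 to compound 4 (within the scatter). For compound 4 in this assay the estimate is therefore 18%, with a likely range from 8% to 30%.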

Compound 4, largest response reached (reported as percent of maximum), in percent of the reference or control that the assay uses: 24.2%
Estimate against measurement, compound 4: 6.2 percentage points below; measured number inside the range.
By their numbers in this assay, from the lowest: compounds 1, 4, 2 and 3 (each within the scatter of the next, the first and the last beyond it).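

On the core of compound 2, the exchange of 2-carboxyphenyl for 4-(methoxycarbonyl)phenyl gives a number 3.8 percentage points lower from compound 2 to compound 4 (within the scatter) in this assay, so here this change cannot be told apart from scatter, unlike its reading on the core of compound 1. Even so, the two readings of the exchange do not truly disagree: the same change on two cores in this assay, a number 10.9 percentage points higher (beyond the scatter) from compound 1 to compound 3 and a number 3.8 percentage points higher (within the scatter) from compound 4 to compound 2, 7.1 percentage points apart, within the scatter of two such steps. The swap between hydroxy and methyl, now also read on the 4-(methoxycarbonyl)phenyl series, gives a number 2.2 percentage points higher from compound 1 to compound 4 (within the scatter), and its two readings agree in the same way: the same change on two cores in this assay, a number 4.9 percentage points higher (within the scatter) from compound 2 to compound 3 and a number 2.2 percentage points lower (within the scatter) from compound 4 to compound 1, 7.1 percentage points apart, within the scatter of two such steps.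

As far as these compounds go, it remains open whether a tail carrying an amine, or a longer chain in place of the present one, would shift the response beyond the scatter. Two cores also cannot show whether either change would behave the same way on a third.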